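Fluoro Added to the Aminophenyl Ring of Compound 1

The source may report more compounds than this note shows. Statements on the series, on what has been measured and on what is new or still open speak of the compounds shown alone.

Measured so far:
compound 1, `CC(C)[C@@H](C(=O)Nc1ccc(C(=O)Nc2ccccc2N)cc1)c1ccccc1`: 16%
compound 2, `CC(C)[C@H](C(=O)Nc1ccc(C(=O)Nc2ccccc2N)cc1)c1ccccc1`: 20%

In an assay on isolated protein for inhibition of protein deacetylase HDAC6 (Homo sapiens), read by fluorescence, tested at 1 uM (a higher number here means more inhibition at the concentration tested (going by the name of the read-out), a lower number less inhibition), compound 1 gives 16%, the lowest of the two numbers. Compound 2 gives 20%. The step of a number 4 percentage points higher from compound 1 to compound 2 (within the scatter) lies within the scatter, and the fact that compounds 1 and 2 differ only in the configuration as drawn is all that separates them. Compound 3 `CC(C)[C@@H](C(=O)Nc1ccc(C(=O)Nc2ccc(F)cc2N)cc1)c1ccccc1` differs from compound 1 by fluoro in place of hydrogen on an aromatic carbon. Going by the values given here, no measured step bears directly on this change; the only measured step, a number 4 percentage points higher from compound 1 to compound 2 (within the scatter), concerns configuration alone and is within the scatter. For compound 3 a step of a number 2 percentage points higher from compound 1 to compound 3 (within the scatter) is expected, none beyond the scatter. The estimate for compound 3 is 18%, ranging from 6% to 35%.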

Compound 3, a percentage reported as inhibition, at one concentration (the size of the read-out at that concentration, not a potency): 0%
Estimate against measurement, compound 3: 18 percentage points above, outside the stated range (below it).
By their numbers in this assay, from the lowest: compound 3; then compounds 1 and 2 (each within the scatter of the next).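

In this assay, fluoro in place of hydrogen, meta to the amino group and para to a large group, comes with a number 16 percentage points lower from compound 1 to compound 3 (beyond the scatter). This position on the 2-aminophenyl ring therefore responds to a change of a single heavy atom, something the pair differing only in configuration could not show. Going by these compounds alone, nothing measured so far accounts for the drop. From the compounds shown here alone, whether chloro or a methyl group at this place would give a similar drop remains open. So does whether fluoro would do the same on compound 2.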